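The compounds below may be only part of what the source reports. "The series", "measured", "known", "first", "only" and "open" are said of these compounds alone.

Compound 1 `COC(=O)Cn1cc(CO[C@H]2CC(=O)[C@@H]3OC[C@H]2O3)nn1` gives 21300 nM in a functional assay on MDA-MB-231 cells (Homo sapiens) for cytotoxicity, read by MTT assay, with a stated time of 48 h (on this read-out lower numbers stand for stronger inhibition and higher numbers for weaker inhibition), and compound 3 `O=C1C[C@H](OCc2cn(-c3ccccc3Br)nn2)[C@H]2CO[C@@H]1O2` gives 22500 nM. Compound 2 `CCCCCCCCn1cc(CO[C@H]2CC(=O)[C@@H]3OC[C@H]2O3)nn1` gives only a limit of the assay, > 50000 nM, a value at the limit of > 50000 nM in this assay, at which 1 of the 3 values shown sits. Compound 2 therefore stands at the edge of what the assay reports, with no number of its own. Compound 4 `COc1ccc(Cn2cc(CO[C@H]3CC(=O)[C@@H]4OC[C@H]3O4)nn2)cc1` differs from compound 2 by 4-methoxyphenyl in place of heptyl on a saturated chain carbon bound to an aromatic nitrogen. For the measured compounds named here, two measured steps bear on this change: an at least 2.2-fold lower number from compound 2 to compound 3 (0.34 log units; beyond the scatter), and an at least 2.3-fold higher number from compound 1 to compound 2 (0.37 log units; beyond the scatter). Both point the same way: replacing the long chain on the aromatic nitrogen brought the number back down into the range shared by compound 1 and compound 3. Compound 4 is therefore expected to move by an at least 2.2-fold lower number from compound 2 to compound 4 (0.35 log units; beyond the scatter). The estimated value of compound 4 is 22000 nM, within a range from 8000 nM to 60000 nM.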

Compound 4, half-maximal inhibitory concentration: 34800 nM
Compound 4: the middle estimate sits 1.6-fold (0.20 log units) below what was measured; the measured number falls inside the stated range.
By their numbers in this assay, from the lowest: compounds 1, 3 and 4 (each within the scatter of the next). At a limit, above all of these: compound 2.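

Compound 4 shows that 4-methoxyphenyl on a saturated chain carbon bound to an aromatic nitrogen gives a measurable number in this assay, whereas compound 2 carries only a limit: the limit of > 50000 nM in this assay, at which 1 of the 4 values shown sits. Replacing heptyl with 4-methoxyphenyl gives an at least 1.4-fold lower number from compound 2 to compound 4 (0.15 log units; that floor lies within the scatter), so the true size of this change remains unfixed. Replacing methoxycarbonyl with 4-methoxyphenyl gives a 1.6-fold higher number from compound 1 to compound 4 (0.21 log units; within the scatter), so these two groups are not told apart here. As far as these compounds go, it remains open whether an amine or a carboxylic acid at this place would move the number beyond the scatter, and whether a shorter chain than heptyl would give a measurable number.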